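A few compounds are considered here, and "the series" means these few. Any claim that something is new, unique, unknown or untested is made for them only; others in the source may bear on it.

Working notes on the series in a functional assay on A2780 cells (Homo sapiens) for antiproliferative activity, read by resazurin assay, with a stated time of 72 h; on this read-out higher numbers stand for weaker inhibition and lower numbers for stronger inhibition
compound 1 `NC(=O)c1cc2c(Cc3ccccc3)n[nH]c2cc1O` gives "not determined" (no result reported)
compound 2 `CN(C(=O)c1cc2c(Cc3ccccc3)n[nH]c2cc1O)c1ccco1` gives 2500 nM
compound 3 `CN(Cc1ccccc1F)C(=O)c1cc2c(Cc3ccccc3)n[nH]c2cc1O` gives 1500 nM

Compound 3 stands level with compound 2 within the scatter, and compound 1 offers no number for comparison. Compound 4 `Cc1ccccc1CN(C)C(=O)c1cc2c(Cc3ccccc3)n[nH]c2cc1O` carries methyl in place of fluoro on an aromatic carbon, ortho to a large group, which turns 2-fluorobenzyl into 2-methylbenzyl methyl in place of fluoro on an aromatic carbon and leaves the rest unchanged. Going by the values given here, the only measured step, a 1.7-fold lower number from compound 2 to compound 3 (0.22 log units; within the scatter), exchanged the whole group on the amide-type nitrogen, and no measured step tests this fluoro. No shift beyond the scatter is therefore expected in this assay and neither direction is favoured. The expected step is a 1.1-fold lower number from compound 3 to compound 4 (0.03 log units; within the scatter) and it stays small. Compound 4 is estimated at 1400 nM with an expected range of 600 nM to 3300 nM in this read-out.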

Compound 4, half-maximal inhibitory concentration: 4400 nM
Estimate against measurement, compound 4: 3.1-fold (0.50 log units) below; the measured number lies above the stated range.
By their numbers in this assay, from the lowest: compounds 3, 2 and 4 (each within the scatter of the next, the first and the last beyond it).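

In this assay, going by these compounds alone, this single-atom exchange on an aromatic carbon, ortho to a large group, gives a 2.9-fold higher number from compound 3 to compound 4 (0.47 log units; beyond the scatter) and so moves the number beyond the scatter, which the only earlier step did not do. Against the furan-2-yl group, 2-methylbenzyl gives a 1.8-fold higher number from compound 2 to compound 4 (0.25 log units; within the scatter) and remains within the scatter, so only the 2-fluorobenzyl and 2-methylbenzyl pair is separated. No supporting measurement bears on the reason for this shift.

As far as these compounds go, whether chloro, methoxy or an amine at this carbon would track fluoro or methyl remains open. Compound 1 supplies no number, so the amide without nitrogen substituents also remains unplaced.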